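The source may report more compounds than this note shows. Statements on the series, on what has been measured and on what is new or still open speak of the compounds shown alone.

In a functional assay on a cell-free system (plasma, Homo sapiens) for inhibition, with Plasma (Rattus norvegicus) as the target (a lower number here means a stronger inhibitor, a higher number a weaker inhibitor), three compounds sharing a core have been measured. Compound 1 `O=c1cc(N2CCNCC2)c2ccc(OCc3ccccc3)cc2o1` gives 78800 nM, compound 2 `Cc1c(OCc2ccccc2)ccc2c(N3CCNCC3)cc(=O)oc12` gives 1100 nM, and compound 3 `CCCCOc1ccc2c(N3CCNCC3)cc(=O)oc2c1C` gives 5030 nM. Compound 3 therefore holds the middle of the three numbers, nearer to compound 2 than to compound 1.

The next structure, compound 4 `CSCCOc1ccc2c(N3CCNCC3)cc(=O)oc2c1C`, alters only the end of the butoxy chain of compound 3: methylsulfanyl in place of ethyl on a saturated chain carbon, two bonds along the chain from an oxygen on an aromatic ring. Butoxy thus becomes 2-(methylsulfanyl)ethoxy. The largest measured change, a 72-fold lower number from compound 1 to compound 2 (1.86 log units; beyond the scatter), came with methyl in place of hydrogen on an aromatic carbon. That methyl is present in both compound 3 and compound 4, so this step says little about the new change.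

The closer guide is a 4.6-fold higher number from compound 2 to compound 3 (0.66 log units; beyond the scatter), a modest step with propyl in place of phenyl on the same oxygen-bound chain. For the measured compounds named here, it shows that this chain can move the number, but no measured compound carries methylsulfanyl, so the direction remains uncertain. A change smaller than that modest step is therefore expected, with no shift beyond the scatter. The expected step is a 1.3-fold lower number from compound 3 to compound 4 (0.10 log units; within the scatter). For compound 4, the estimated value is 4000 nM, with an expected range from 1500 nM to 10500 nM.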

Compound 4, half-maximal inhibitory concentration: 1500 nM
Beside the measured number, compound 4's estimate is 2.7-fold (0.43 log units) above it, within the range that was stated.
By their numbers in this assay, from the lowest: compounds 2 and 4 (each within the scatter of the next); then compound 3; then compound 1.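

In this assay, a change two bonds along the chain from an oxygen on an aromatic ring proved enough to move the number: methylsulfanyl in place of ethyl gave a 3.4-fold lower number from compound 3 to compound 4 (0.53 log units; beyond the scatter). The earlier step on this chain had exchanged phenyl for propyl, whereas here the entering and leaving groups have the same count of heavy atoms, with one sulfur and one carbon in place of two carbons and one hydrogen-bond acceptor gained by the count. A chain without the phenyl of compound 2 could also reach the same level, since (methylsulfanyl)methyl in place of phenyl gave a 1.4-fold higher number from compound 2 to compound 4 (0.13 log units; within the scatter), although the butoxy chain of compound 3 goes against any general reading of this kind.

The compounds shown offer nothing that accounts for the difference between the ethyl and methylsulfanyl groups. Going by these compounds, it remains open whether methoxy in place of methylsulfanyl, giving 2-methoxyethoxy, or a longer chain carrying methylsulfanyl would give a number like that of compound 4, and whether the change would act the same way without the methyl on the aromatic carbon.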